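Ethoxy to hydroxy on compound 2

This account rests on a few compounds, and the source may have more. Where it says the series, first, only, none or still open, it means among the compounds named here.

Compound 1 (`CCOC(=O)C(=O)Nc1nc(-c2ccccc2OC)cs1`) gives > 30 mg/kg in a functional assay on the whole organism with Rattus norvegicus as the target (a higher number here means that more compound is needed for the effect, a lower number that less compound is needed), which is a limit of the assay and not a number. Compound 2 (`CCOC(=O)C(=O)Nc1nc(-c2ccc(OC)cc2OC)cs1`) gives > 30 mg/kg in this assay, again only a limit, so its standing in the series cannot be ranked. Among the measured compounds shown here, the one measured step, a step that the two limits leave unreadable from compound 1 to compound 2, gives no size to carry forward, and it concerns a different place in the molecule from the change considered next.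

Compound 3 (`COc1ccc(-c2csc(NC(=O)C(=O)O)n2)c(OC)c1`) differs from compound 2 by hydrogen in place of ethyl on an oxygen next to a carbonyl group: ethoxycarbonyl becomes carboxy. For the measured compounds named here, no measured step touches this group, so the expectation has only a weak footing. As far as these compounds go, with compound 2 at > 30 mg/kg, a limit, the starting point of the step stays open. A move towards a lower dose is expected tentatively, and compound 3 remaining at a limit is about equally likely. The estimated step, with wide uncertainty, is an at least 1.5-fold lower number from compound 2 to compound 3 (0.17 log units; that floor lies within the scatter). For compound 3 the expected dose is 20 mg/kg, with an estimated range of 4 mg/kg to 60 mg/kg.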

Compound 3, dose for half-maximal effect: > 10 mg/kg
Compound 3: a limit, no number; the forecaster's own chance of this, stated with the estimate: 55%; the middle value does not contradict the limit.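

In this assay compound 3 gives > 10 mg/kg, a limit and not a number. Compound 2 also stands at a limit, so no size can be read for the step between compound 2 and compound 3. The compounds shown leave open whether carboxy in place of ethoxycarbonyl alters the dose needed, and what dose any of the three compounds requires.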